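This account rests on a few compounds, and the source may have more. Where it says the series, first, only, none or still open, it means among the compounds named here.

Measured compounds:
- compound 1 `CCCCCCCCNC(=O)[C@@H](NC(=O)c1ccco1)[C@@H](C)O`: 200000 nM
- compound 2 `CCCCCCCCCCCCCCNC(=O)[C@@H](NC(=O)c1ccccc1)[C@@H](C)O`: 200000 nM

In a functional assay on SW-620 cells (Homo sapiens) for cytotoxicity, read by MTT assay, with a stated time of 48 h (a lower number here means a stronger inhibitor, a higher number a weaker inhibitor), compound 1 gives 200000 nM. In this assay compound 2 gives 200000 nM, level with compound 1 at the digits shown, within the scatter. For the measured compounds named here, both compounds share the same core and differ in the amide chain and in the aromatic ring on the other carbonyl; no single-point step between them is available, so the two values say only that neither change shifted the number.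

Compound 3 `CCCCCCCCCCCCCCNC(=O)[C@@H](NC(=O)c1ccco1)[C@@H](C)O` combines the tetradecyl chain of compound 2 with the ring of compound 1. The change from compound 2 is furan-2-yl in place of phenyl on a carbonyl carbon. With compound 1 at 200000 nM already carrying this ring on a shorter chain without any shift, no step beyond the scatter is expected in this assay. The expected step is no change at the digits printed from compound 2 to compound 3 (within the scatter). Compound 3 is expected at 200000 nM, range 100000 nM to 400000 nM.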

Compound 3, half-maximal inhibitory concentration: 200000 nM
Compound 3: middle estimate and measured number agree at the digits printed; the measured number falls inside the stated range.
By their numbers in this assay, from the lowest: compounds 1, 2 and 3 (each within the scatter of the next).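

In this assay, furan-2-yl in place of phenyl on a carbonyl carbon gives no change at the digits printed from compound 2 to compound 3 (within the scatter), so the ring change can now be read by itself on the longer chain, which compound 1 and compound 2 alone did not allow. With the furan-2-yl ring held constant, hexyl in place of hydrogen on a saturated chain carbon, eight bonds along the chain from an amide-type nitrogen, gives no change at the digits printed from compound 1 to compound 3 (within the scatter), so the chain change can also be read by itself. No supporting measurement is available to explain these results.

As far as these compounds go, whether an amine on the furan-2-yl ring, or a carboxylic acid in place of the hydroxyl on the shared core, would move the number in this assay remains open. With all three compounds level, the series does not yet show which part of the structure, if any, can shift this read-out.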